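The source may report more compounds than this note shows. Statements on the series, on what has been measured and on what is new or still open speak of the compounds shown alone.

Measured compounds:
- compound 1, `O=Cc1ccc(-c2cncc(Cl)c2N2CCC3(CCNC3=O)CC2)o1`, gives 5190 nM in a functional assay on MV4-11 cells (Homo sapiens) for inhibition, read by resazurin assay, with a stated time of 72 h; on this read-out higher numbers stand for weaker inhibition of growth and lower numbers for stronger inhibition of growth
- compound 2, `O=C1NCCC12CCN(c1c(Cl)cncc1-c1ccc(Cl)s1)CC2`, gives 560 nM in this assay

Compound 2 stands at the lowest of the two numbers; its nearest neighbour is compound 1, and the only step shown, a 9.3-fold lower number from compound 1 to compound 2 (0.97 log units; beyond the scatter), lies beyond the scatter. Among the compounds with values here, that step is the sole guide for the next change: the five-membered aromatic ring attached to the shared core was exchanged, and the read-out moved by a clear margin.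

Compound 3, `Cn1cccc1-c1cncc(Cl)c1N1CCC2(CCNC2=O)CC1`, carries the same core and differs from compound 2 in one place: 1-methyl-1H-pyrrol-2-yl in place of 5-chlorothiophen-2-yl on an aromatic carbon. This is again an exchange of the five-membered aromatic ring on the same position, so the step from compound 1 to compound 2 is the relevant precedent. Within the data shown here, it shows that such an exchange can shift the number clearly, as a 9.3-fold lower number from compound 1 to compound 2 (0.97 log units; beyond the scatter) does, but with only one example the direction for a new ring cannot be read off. The expectation is therefore a step back toward compound 1, of moderate size, with wide uncertainty: compound 3 is estimated at 1500 nM, between 400 nM and 6000 nM, which would mean a 2.7-fold higher number from compound 2 to compound 3 (0.43 log units; beyond the scatter).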

Compound 3, concentration for 50% growth inhibition: 900 nM
Compound 3: middle estimate off by 1.7-fold (0.22 log units), on the high side; the measured number falls inside the stated range.
By their numbers in this assay, from the lowest: compounds 2 and 3 (each within the scatter of the next); then compound 1.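

Exchanging 5-chlorothiophen-2-yl for 1-methyl-1H-pyrrol-2-yl gives a 1.6-fold higher number from compound 2 to compound 3 (0.21 log units; within the scatter), so in this assay compound 2 and compound 3 cannot be told apart, even though one ring carries sulfur and chlorine and the other nitrogen and a methyl group. The clear gap to compound 1 is therefore no longer tied to the 5-chlorothiophen-2-yl group alone: a second, quite different five-membered aromatic ring also stands apart from 5-formylfuran-2-yl, with a 5.8-fold lower number from compound 1 to compound 3 (0.76 log units; beyond the scatter), and of the three compounds only compound 1, with its formyl-bearing furan, sits at the high end of the read-out. Nothing measured here gives a reason for these numbers.

The compounds shown leave open whether the formyl group or the furan ring sets compound 1 apart, a question that a plain furan-2-yl group in the same place would address. They also leave open how this place responds to a six-membered aromatic ring such as phenyl, or to a five-membered ring carrying an amine or a carboxylic acid.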